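A few compounds are considered here, and "the series" means these few. Any claim that something is new, unique, unknown or untested is made for them only; others in the source may bear on it.

Measured so far in a physicochemical assay for solubility; a lower number here means a less soluble compound, a higher number a more soluble compound
Compound 1 `CN(Cc1ccc2nccn2c1)c1nnc(-c2ccc(OC3CCCC3)cc2)o1` gives 33000 nM
Compound 2 `CNc1nc(OC2CCCC2)nc2c1ncn2Cc1c(F)cccc1F` gives 9000 nM
Compound 3 `CNC(=O)c1sc(N2CC3CC2(CNC(=O)c2c[nH]c4ncccc24)C3)nc1C(F)(F)F` gives < 1600 nM (a limit, not a number)

Compound 3 has no exact reading, only the limit < 1600 nM. The other two compounds do have exact readings, and both lie on the more soluble side of that limit. Their cores differ from the core of compound 3, so they say little about what comes next.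

Compound 4 `CNC(=O)c1sc(N2CC3CC2(CNC(=O)c2c[nH]c4ncc(Cl)cc24)C3)nc1C(F)(F)F` is compound 3 with one change: chloro in place of hydrogen on an aromatic carbon, on a six-membered aromatic ring with 1 nitrogen, two atoms from the ring nitrogen (chloro in place of hydrogen on an aromatic carbon). Within the data shown here, no two measured compounds differ in just one place, so no measured step can serve as a guide for this change. The expectation in this assay is therefore a small step downward, or none beyond the scatter, and a second report of only a limit would be no surprise. The estimated size of the change is a step that the limit leaves unreadable from compound 3 to compound 4, a loose figure that starts from a limit rather than a number. For compound 4 the estimated value is 1000 nM, with an expected range from 300 nM to 2500 nM.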

Compound 4, solubility: 2000 nM
Compound 4: middle estimate off by 2.0-fold (0.30 log units), on the low side; measured number inside the range.
By their numbers in this assay, from the lowest: compound 4; then compound 2; then compound 1. At a limit, below all of these: compound 3.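

On the core shared by compound 3 and compound 4, this assay first offers only a limit: compound 3 stands at < 1600 nM, which is a limit and not a number. Chloro in place of hydrogen on an aromatic carbon, two atoms from the ring nitrogen, gives an at least 1.2-fold higher number from compound 3 to compound 4 (0.09 log units; that floor lies within the scatter), and among the compounds shown, compound 4 at 2000 nM is the only exact reading for this core. The step can be stated only as a floor, and its true size stays unknown, because its starting point is a limit: the limit of < 1600 nM in this assay, at which 1 of the 4 values shown sits.

On these data alone, it remains open whether the true step from hydrogen to chloro lies beyond the usual scatter, since only an exact reading for the compound without chloro could settle that. Also open, as far as these compounds go, is what another group at the same aromatic carbon, such as an amine or a carboxylic acid, would do to the reading, and whether chloro would give a similar step on the core of compound 1 or the core of compound 2.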